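Cyclohexyl to 3-(dimethylamino)phenyl on the shared core

The source may hold more compounds than are shown below. What is called first, only, known or untested is meant among the compounds shown, and "the series" means these compounds.

Measured so far:
compound 1 `CN1CCN(CCNCc2cn(-c3ccc(F)cc3F)nc2C2CCCCC2)CC1`, > 20000 nM
compound 2 `CN1CCN(CCCNCc2cn(-c3ccc([N+](=O)[O-])cc3)nc2-c2ccc(Cl)cc2)CC1`, 3700 nM

In an ADME assay on Huh-7 cells (Homo sapiens) for cytotoxicity (on this read-out lower numbers stand for higher toxicity in this test and higher numbers for lower toxicity in this test), compound 1 gives > 20000 nM, which is a limit of the assay rather than a number. Compound 1 stands at the limit of > 20000 nM in this assay, at which 1 of the 2 values shown sits. Compound 2, which carries a different aryl group and a different side chain, gives 3700 nM in this assay. Compound 3 `CN1CCN(CCNCc2cn(-c3ccc(F)cc3F)nc2-c2cccc(N(C)C)c2)CC1` is not yet measured; it differs from compound 1 by 3-(dimethylamino)phenyl in place of cyclohexyl on an aromatic carbon. For the measured compounds named here, no step between measured compounds is available to size this change; with one value a limit, a moderate step toward lower numbers is expected, as an at least 2.0-fold lower number from compound 1 to compound 3 (0.30 log units; that floor lies within the scatter). Compound 3 is estimated at 10000 nM, between 3500 nM and 30000 nM.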

Compound 3, half-maximal cytotoxic concentration: > 20000 nM
Compound 3: a limit, no number (the forecaster's own chance of this, stated with the estimate: 35%); middle value at least 2.0-fold (0.30 log units) from the limit.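

In this assay, for the compounds shown here, compound 3 gives > 20000 nM, a limit and not a number, like compound 1, and no step between the two can be read. The compounds shown leave open how far 3-(dimethylamino)phenyl in place of cyclohexyl shifts this read-out.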